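This account rests on a few compounds, and the source may have more. Where it says the series, first, only, none or still open, it means among the compounds named here.

Compound 3 `C[C@H](F)[C@H]1C(=O)N2C(C(=O)O)=C(C(C)(C)C)O[C@H]12` gives 7.2 h in an ADME assay, in phosphate buffer, at 28 degrees C, at pH 7.0; on this read-out lower numbers stand for a shorter-lived compound and higher numbers for a longer-lived compound; it sits among three numbers that all lie within the scatter of one another, with compound 1 `C[C@@H](O)[C@H]1C(=O)N2C(C(=O)O)=C(C(C)(C)C)O[C@H]12` at 8.1 h and compound 2 `C[C@H](O)[C@H]1C(=O)N2C(C(=O)O)=C(C(C)(C)C)O[C@H]12` at 7.1 h. The measured steps are small: a 1.1-fold lower number from compound 1 to compound 2 (0.06 log units; within the scatter), a pair that differs only in configuration (the fact that compounds 1 and 2 differ only in the configuration as drawn), then a 1.1-fold lower number from compound 1 to compound 3 (0.05 log units; within the scatter) and a 1.0-fold higher number from compound 2 to compound 3 (0.01 log units; within the scatter). Compound 4 `CC(C)(C)C1=C(C(=O)O)N2C(=O)[C@H](CNS(C)(=O)=O)[C@H]2O1` brings the change ((methanesulfonamido)methyl in place of 1-fluoroethyl on a saturated ring carbon). For the measured compounds named here, no measured step covers a replacement of this kind; the nearest comparison, a 1.0-fold higher number from compound 2 to compound 3 (0.01 log units; within the scatter), exchanged one small substituent for another at the same carbon and stayed within the scatter. For compound 4 the expectation in this assay is therefore no step beyond the scatter, a 1.1-fold lower number from compound 3 to compound 4 (0.04 log units; within the scatter), with an estimate of 6.5 h and a range from 3.5 h to 12 h.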

Compound 4, half-life: 2.2 h
For compound 4 the middle estimate is 3.0-fold (0.47 log units) above the measured one; measured number below the stated range.
By their numbers in this assay, from the lowest: compound 4; then compounds 2, 3 and 1 (each within the scatter of the next).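

In this assay the saturated ring carbon proves sensitive to its substituent: a 3.3-fold lower number from compound 3 to compound 4 (0.51 log units; beyond the scatter), a 3.2-fold lower number from compound 2 to compound 4 (0.51 log units; beyond the scatter) and a 3.7-fold lower number from compound 1 to compound 4 (0.57 log units; beyond the scatter). The 1-hydroxyethyl and 1-fluoroethyl compounds lie within the scatter of one another, and among the compounds shown only (methanesulfonamido)methyl gives a number beyond it. Nothing at hand bears on what lies behind this shorter half-life.

Compound 4 exchanges the whole substituent in one step, leaving open which part of (methanesulfonamido)methyl goes with the lower number. An aminomethyl group at this carbon, or a longer chain ending in methanesulfonamide, would separate the parts.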